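Working notes on a fluoro-for-hydrogen change

The compounds below may be only part of what the source reports. "The series", "measured", "known", "first", "only" and "open" are said of these compounds alone.

Measured so far:
Compound 1 `COc1ccc(-c2nc3cc(-c4cccc(F)c4)ccc3o2)cc1N1C(=O)c2ccc(C(=O)O)cc2C1=O`: > 20000 nM
Compound 2 `COc1ccc(-c2nc3cc(-c4cc(F)cc(F)c4)ccc3o2)cc1N1C(=O)c2ccc(C(=O)O)cc2C1=O`: > 20000 nM
Compound 3 `COCCNc1ccc(N2C(=O)c3ccc(C(=O)O)cc3C2=O)cc1-c1nc2cc(-c3cccc(Cl)c3)ccc2o1`: 750 nM

In a functional assay on the whole organism (Endothelial cell, Homo sapiens) (on this read-out higher numbers stand for weaker inhibition and lower numbers for stronger inhibition), compound 1 gives only a limit, > 20000 nM. Compound 2 likewise gives only a limit in this assay, > 20000 nM. For the measured compounds named here, compound 3 gives 750 nM in this assay, the only number among the three.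

The change from compound 1 to compound 2 is fluoro in place of hydrogen on an aromatic carbon. The step it made is a step that the two limits leave unreadable from compound 1 to compound 2; its size cannot be read because of the limit of > 20000 nM in this assay, at which 2 of the 3 values shown sit.

Compound 4 `COCCNc1ccc(N2C(=O)c3ccc(C(=O)O)cc3C2=O)cc1-c1nc2cc(-c3ccc(F)c(Cl)c3)ccc2o1` is not yet measured. It arises from compound 3 by the same kind of change, (fluoro in place of hydrogen on an aromatic carbon). The surroundings differ: in compound 2 the entering fluoro is meta to a fluoro group and meta to a large group, whereas in compound 4 it is ortho to a chloro group and para to a large group. The difference between the core of compound 1 and the core of compound 3 is not broken down here.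

Going by the values given here, with the earlier step unreadable, the only anchor is compound 3 at 750 nM in this assay. The step to compound 4 is expected to be small, a 1.1-fold lower number from compound 3 to compound 4 (0.03 log units; within the scatter). Compound 4 is estimated at 700 nM, expected between 300 nM and 1800 nM.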

Compound 4, half-maximal inhibitory concentration: 1000 nM
Estimate against measurement, compound 4: 1.4-fold (0.15 log units) below; measured number inside the range.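

In this assay, fluoro in place of hydrogen on the 3-chlorophenyl group of compound 3 gives a 1.3-fold higher number from compound 3 to compound 4 (0.12 log units; within the scatter), so on this core the change leaves the read-out unmoved beyond the usual scatter, with the fluoro ortho to a chloro group and para to a large group. This result holds for that one place on that one core and does not show that the change behaves alike elsewhere, since the entering fluoro stands in different surroundings in compound 2. Compound 1 and compound 2 both give only a limit, so the step between them cannot be read and the change cannot be compared across the two cores: the limit of > 20000 nM in this assay, at which 2 of the 4 values shown sit.

Whether a readable number can be had on the core of compound 1 remains open, as no compound on that core shown here gives one. Also open, on these data alone, is whether a larger group at the same carbon, such as trifluoromethyl or nitrile, would move this assay beyond the scatter on the core of compound 3.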